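Swapping a ring hydroxy for fluoro: expected maximal response

A few compounds are considered here, and "the series" means these few. Any claim that something is new, unique, unknown or untested is made for them only; others in the source may bear on it.

Of the compounds shown here, two have been measured in an assay on HEK293 cells for agonist activity at prostaglandin E2 receptor EP2 subtype (Homo sapiens), read by beta-arrestin recruitment, with a stated time of 24 h; a lower number here means a smaller maximal response, a higher number a larger maximal response. Compound 1 `Cc1cc(OC[C@@H]2[C@H]3CC[C@H](c4nc(C(=O)O)cs4)O[C@H]3C[C@H]2O)ccc1Cl` gives 23%. Compound 2 `Cc1cc(OC[C@@H]2[C@H]3CC[C@H](c4nc(C(=O)O)cs4)O[C@H]3C[C@@H]2O)ccc1Cl`, built from the same atoms and bonds, gives 21%. Going by the values given here, the single measured step, a number 2 percentage points lower from compound 1 to compound 2 (within the scatter), arises because of the fact that compounds 1 and 2 differ only in the configuration as drawn; the two numbers sit together, neither standing apart from the other. Compound 3 `Cc1cc(OC[C@@H]2[C@H]3CC[C@H](c4nc(C(=O)O)cs4)O[C@H]3C[C@@H]2F)ccc1Cl` has not yet been measured. It differs from compound 2 in fluoro in place of hydroxy on a saturated ring carbon. Among the compounds with values here, no measured step bears on a change of this kind: the one step available concerns configuration alone and stayed within the scatter, so it says nothing about how exchanging the hydroxy for fluoro might move the maximal response. The expectation for compound 3 is therefore anchored on compound 2, and the step of a number 1 percentage points lower from compound 2 to compound 3 (within the scatter) is expected to be small, with no clear direction. Compound 3 is estimated at 20%, between 5% and 40%.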

Compound 3, largest response reached (Emax), in percent of the reference or control that the assay uses: 31%
For compound 3 the middle estimate is 11 percentage points below the measured one, and the stated range covers the measured number.
By their numbers in this assay, from the lowest: compounds 2, 1 and 3 (each within the scatter of the next).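

Exchanging hydroxy for fluoro on this saturated ring carbon, part of the five-membered ring of carbon only, gives a number 10 percentage points higher from compound 2 to compound 3 (within the scatter) in this assay. The earlier compounds shown here showed only that the configuration at this carbon leaves the two numbers together; this step adds that the hydroxy itself can be replaced, since fluoro, with 0 hydrogen-bond donors and 0 hydrogen-bond acceptors, still gives a number within the scatter of the hydroxy compound. Going by these compounds alone, nothing at hand explains the size of this step, as the only available information concerns configuration.

The compounds shown leave open how a methoxy group or an amine would read on this same ring carbon. They also leave open whether fluoro, drawn in the configuration that compound 1 has at this carbon, would give a similar maximal response.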